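The source may report more compounds than this note shows. Statements on the series, on what has been measured and on what is new or still open speak of the compounds shown alone.

Measured compounds in a functional assay on MGC-803 cells (Homo sapiens) for inhibition, read by MTT assay, with a stated time of 48 h; on this read-out higher numbers stand for weaker inhibition and lower numbers for stronger inhibition:
compound 1, `COc1ccc(CN(C(=O)C2CC2)c2cc(OC)c(OC)c(OC)c2)cc1O`: compound 1 gives 59 nM
compound 2, `COc1ccc(CN(C(C)=O)c2cc(OC)c(OC)c(OC)c2)cc1O`: compound 2 gives 79 nM
compound 3, `C=C(C)C(=O)N(Cc1ccc(OC)c(O)c1)c1cc(OC)c(OC)c(OC)c1`: compound 3 gives 390 nM

Compound 3 stands highest of the three in this assay: the steps of a 6.6-fold higher number from compound 1 to compound 3 (0.82 log units; beyond the scatter) and a 4.9-fold higher number from compound 2 to compound 3 (0.69 log units; beyond the scatter) are both beyond the scatter, whereas a 1.3-fold higher number from compound 1 to compound 2 (0.13 log units; within the scatter) lies within it. Compound 4, `COCC(=O)N(Cc1ccc(OC)c(O)c1)c1cc(OC)c(OC)c(OC)c1`, differs from compound 3 by methoxymethyl in place of 1-methylethenyl on a carbonyl carbon. Among the compounds with values here, the two measured steps that bear on this position both introduce 1-methylethenyl, with its double bond outside aromatic rings, and both run to a higher number; the present change removes that group again for one without a double bond, so a lower number is expected, though no measured step covers methoxymethyl itself. On this basis compound 4 is estimated at 100 nM (range 40 nM to 300 nM). The expected step is a 3.9-fold lower number from compound 3 to compound 4 (0.59 log units; beyond the scatter).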

Compound 4, half-maximal inhibitory concentration: 79 nM
The estimate for compound 4 lay 1.3-fold (0.10 log units) above the measured number; low and high end bracket the measured number.
By their numbers in this assay, from the lowest: compounds 1, 2 and 4 (each within the scatter of the next); then compound 3.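

In this assay, methoxymethyl on the carbonyl carbon gives a 4.9-fold lower number from compound 3 to compound 4 (0.69 log units; beyond the scatter), so replacing 1-methylethenyl here restores the lower numbers. The other two steps, no change at the digits printed from compound 2 to compound 4 (within the scatter) and a 1.3-fold higher number from compound 1 to compound 4 (0.13 log units; within the scatter), lie within the scatter, so methoxymethyl cannot be told apart from methyl or cyclopropyl, and among these compounds only 1-methylethenyl stands apart. Nothing available explains this result. As far as these compounds go, what remains open is whether an isopropyl group, which lacks the double bond of 1-methylethenyl, would stay with the lower numbers. From the compounds shown here alone, how an amine, a carboxylic acid or a longer ether chain would read at this position also remains open.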